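A few compounds are considered here, and "the series" means these few. Any claim that something is new, unique, unknown or untested is made for them only; others in the source may bear on it.

Of the compounds shown here, three built around the same general design have been tested in a functional assay on A549 cells (Homo sapiens) for antiproliferative activity, read by MTT assay, with a stated time of 72 h; on this read-out lower numbers stand for stronger inhibition and higher numbers for weaker inhibition. Compound 1 `CC/C=C/C(=O)Nc1cccc(Oc2nc(Nc3cccc(C#N)c3)nc3c2CSCC3)c1` gives 10100 nM in this assay. Compound 2 `CCC/C=C/C(=O)Nc1cccc(Oc2nc(Nc3cccc(C#N)c3)nc3c2CSCC3)c1` carries one more carbon on its chain, and in this assay compound 2 gives 5790 nM. The change between them is methyl in place of hydrogen on a saturated chain carbon, two bonds along the chain from a double-bonded chain carbon, and it made a step of a 1.7-fold lower number from compound 1 to compound 2 (0.24 log units; within the scatter), so the two numbers cannot be told apart with confidence. Compound 3 `C/C=C/C(=O)Nc1cccc(Oc2nc(Nc3ccc(OC)cc3)nc3c2CSCC3)c1` belongs to a second core; how the core of compound 3 differs from the core of compound 1 is not broken down here. In this assay compound 3 gives 22200 nM, the highest of the three numbers, and its gaps to compound 1 and to compound 2 are beyond the scatter.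

Compound 4 `CC/C=C/C(=O)Nc1cccc(Oc2nc(Nc3ccc(OC)cc3)nc3c2CSCC3)c1` is the next member of the second core and has not yet been measured. It differs from compound 3 by methyl in place of hydrogen on a saturated chain carbon bound to a double-bonded chain carbon. Among the compounds with values here, this is the same kind of change as the one from compound 1 to compound 2, but not the same: there the added carbon sat two bonds along the chain from a double-bonded chain carbon, here it sits on a saturated chain carbon bound to a double-bonded chain carbon. Since the earlier step of a 1.7-fold lower number from compound 1 to compound 2 (0.24 log units; within the scatter) stayed within the scatter, the expected step from compound 3 to compound 4 is likewise modest, at a 1.5-fold lower number from compound 3 to compound 4 (0.17 log units; within the scatter). In this assay compound 4 is therefore estimated at 15000 nM, with an expected range from 7000 nM to 33000 nM.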

Compound 4, half-maximal inhibitory concentration: 20100 nM
For compound 4 the middle estimate is 1.3-fold (0.13 log units) below the measured one, within the range that was stated.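

In this assay the added methyl gives a 1.1-fold lower number from compound 3 to compound 4 (0.04 log units; within the scatter), so compound 3 and compound 4 cannot be told apart, and this step does not differ measurably from the one seen on the other core: the same change on two cores in this assay, a 1.7-fold lower number (0.24 log units; within the scatter) from compound 1 to compound 2 and a 1.1-fold lower number (0.04 log units; within the scatter) from compound 3 to compound 4, 1.6-fold (0.20 log units) apart, within the scatter of two such steps. Within the data shown here, this suggests that adding one carbon to the chain makes no change large enough to detect on either core, but it does not show that a real effect carries over from one core to the other, since both steps are too small to separate from scatter, each core offers only one pair, and the added carbon sits at a different place on the chain in each pair. Putting 4-methoxyphenyl in place of 3-cyanophenyl, with the chain left the same, gives a 2.0-fold higher number from compound 1 to compound 4 (0.30 log units; within the scatter), so this pair also stays within the scatter and gives no firm sign that the aromatic group matters.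

The compounds shown leave open whether a longer chain, such as hex-1-en-1-yl, would move the number beyond the scatter on either core. They also leave open what a chain carrying an amine would do.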